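The source may report more compounds than this note shows. Statements on the series, on what has been measured and on what is new or still open speak of the compounds shown alone.

The measured compounds:
compound 1, `C=CCOCCn1c(N2CCCN(C)CC2)nc2ccccc21`, gives 10 nM in a functional assay on ileum for inhibition of histamine H1 receptor (Cavia porcellus); a lower number here means a stronger inhibitor, a higher number a weaker inhibitor
compound 2, `CCCCN1CCCN(c2nc3ccccc3n2CCOCC)CC1`, gives 8.4 nM
compound 3, `CCSCCn1c(N2CCN(C)CC2)nc2ccccc21`, gives 19 nM

In this assay compound 3 and compound 1 give numbers that lie within the usual scatter of each other; only compound 2 gives a number beyond the scatter, a lower one. Compound 4, `CCCCCCCCCCn1c(N2CCN(C)CC2)nc2ccccc21`, has not been measured. It differs from compound 3 by octyl in place of ethylsulfanyl on a saturated chain carbon, two bonds along the chain from an aromatic nitrogen. Among the compounds with values here, no measured pair shows a change of this kind, so nothing among the known numbers tells how far it moves the read-out. For compound 4 the expected step is a 1.6-fold higher number from compound 3 to compound 4 (0.20 log units; within the scatter), toward a somewhat higher number and hardly beyond the scatter. The estimate for compound 4 is 30 nM, within a range from 8 nM to 120 nM.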

Compound 4, half-maximal inhibitory concentration: 4200 nM
Beside the measured number, compound 4's estimate is 140-fold (2.15 log units) below it, outside the stated range (above it).
By their numbers in this assay, from the lowest: compounds 2, 1 and 3 (each within the scatter of the next, the first and the last beyond it); then compound 4.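

In this assay the swap of ethylsulfanyl for octyl gives a 220-fold higher number from compound 3 to compound 4 (2.34 log units; beyond the scatter) and so shows that one change on this chain can weaken inhibition far beyond the scatter. The earlier compounds shown here offered no such comparison, and all three carry oxygen or sulfur in this chain. Nothing measured here explains the loss.

The swap adds chain carbons and removes the sulfur together, leaving open which of the two matters. A short propyl chain and a longer chain that keeps an ether oxygen would be the groups to tell these apart.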